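A few compounds are considered here, and "the series" means these few. Any claim that something is new, unique, unknown or untested is made for them only; others in the source may bear on it.

Compound 1 `O=C(Nc1cccc([N+](=O)[O-])c1)N1CCN(S(=O)(=O)c2sccc2-c2ccccc2Oc2ccc(O)c(O)c2)CC1`: > 20000 nM
Compound 2 `COc1ccc(Oc2ccccc2-c2ccsc2S(=O)(=O)N2CCN(C(=O)Nc3cccc([N+](=O)[O-])c3)CC2)cc1OC`: > 20000 nM

Both compounds were tested in an ADME assay on HEK-293T cells (Homo sapiens) for cytotoxicity, read by CCK-8 assay, with a stated time of 48 h; on this read-out lower numbers stand for stronger inhibition and higher numbers for weaker inhibition. Compound 1 gives > 20000 nM, which is a limit of the assay and not a number. Compound 2 gives > 20000 nM, which is also a limit. The picture so far is therefore a single shared limit: the limit of > 20000 nM in this assay, at which 2 of the 2 values shown sit. No true value is known for either compound, so compound 1 can only be placed at this limit and not ranked against compound 2.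

The next compound is compound 3 `O=C(Nc1ccc(F)cc1)N1CCN(S(=O)(=O)c2sccc2-c2ccccc2Oc2ccc(O)c(O)c2)CC1`. It has 4-fluorophenyl in place of 3-nitrophenyl on an amide-type nitrogen. For the measured compounds named here, the only measured step, a step that the two limits leave unreadable from compound 1 to compound 2, changes a different place in the molecule and gives no readable size, so it offers only weak guidance.

Going by the values given here, with no measured step at this place, no step beyond the usual scatter is expected in this assay, and no direction can be favoured. The expected step is a step that the limit leaves unreadable from compound 1 to compound 3. Compound 3 is estimated at 30000 nM, with an expected range of 10000 nM to 80000 nM, and it may well be reported as a limit again.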

Compound 3, half-maximal inhibitory concentration: 15500 nM
Compound 3: the middle estimate sits 1.9-fold (0.29 log units) above what was measured, within the range that was stated.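

For the compounds shown here, at this position, the change from 3-nitrophenyl to 4-fluorophenyl on the amide-type nitrogen brings the first true number in this assay, where compound 3 gives 15500 nM as a real reading. Compound 1 carries > 20000 nM as a limit and not a number. The change therefore gives an at least 1.2-fold lower number from compound 1 to compound 3 (0.11 log units; that floor lies within the scatter) as its only readable size, so the true step may be larger, but what can be read does not go beyond the usual scatter, and most of the series still sits at one shared limit: the limit of > 20000 nM in this assay, at which 2 of the 3 values shown sit.

The compounds shown leave open whether the loss of the nitro group or the arrival of the fluorine lies behind this reading, as both changed in a single step, and a plain phenyl or a 3-fluorophenyl on the same nitrogen would help to separate the two. They also leave open whether the 3,4-dimethoxyphenyl of compound 2, paired with 4-fluorophenyl on that nitrogen, would give a true number as well, and the step between the two limits cannot be read.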